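The compounds below may be only part of what the source reports. "The series", "measured", "known", "first", "only" and "open" are said of these compounds alone.

Compound 1 `CC(C)=CCC1Cc2c(OCc3ccccc3)cc(=O)n(CCCO)c2CC1(C)C` stands lowest of the three numbers in hand: in a functional assay on PANC-1 cells (Homo sapiens) for inhibition, read by MTT assay, with a stated time of 24 h, tested at 10 uM (a higher number here means more inhibition at the concentration tested (going by the name of the read-out), a lower number less inhibition), compound 1 gives -0.3%. Compound 2 `CC(C)=CCC1Cc2c(OCCCNS(=O)(=O)c3ccc(C(F)(F)F)cc3)cc(=O)n(CCCO)c2CC1(C)C` gives 29.6% in this assay, and compound 3 `CC(C)=CCC1Cc2c(OCCCNS(=O)(=O)c3ccc(Br)cc3)cc(=O)n(CCCO)c2CC1(C)C` gives 19.5%. For the measured compounds named here, the only single-point step with a number attached is a number 10.1 percentage points lower from compound 2 to compound 3 (beyond the scatter), a bromo in place of trifluoromethyl on an aromatic carbon.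

Compound 4 `CC(C)=CCC1Cc2c(OC(=O)Nc3ccc(F)cc3)cc(=O)n(CCCO)c2CC1(C)C` differs from compound 1 by (4-fluorophenyl)carbamoyl in place of benzyl on an oxygen on an aromatic ring. Going by the values given here, no measured step bears directly on this change: the step from compound 2 to compound 3 alters a group on an aromatic carbon of the sulfonamide chain, not the oxygen on the aromatic ring of the core, and no pair with a single change at that oxygen has been measured. Among the compounds with values here, what compounds 2 and 3 show against compound 1 is only that exchanging the benzyl on that oxygen for a longer chain ending in a sulfonamide went with higher readings; each of those exchanges involves more than one change, so no single step separates them. A modest rise is therefore expected in this assay, though with a wide range given the absence of a matching step. Compound 4 is estimated at 10%, from -8% to 30%. The expected step is a number 10.3 percentage points higher from compound 1 to compound 4 (beyond the scatter).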

Compound 4, a percentage reported as inhibition, at one concentration (the size of the read-out at that concentration, not a potency): 71.2%
Compound 4: the middle estimate sits 61.2 percentage points below what was measured; measured number outside the range, above it.
By their numbers in this assay, from the lowest: compound 1; then compound 3; then compound 2; then compound 4.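

In this assay, the oxygen on an aromatic ring of the shared core proves to be a place where one change alone moves the reading, with a number 71.5 percentage points higher from compound 1 to compound 4 (beyond the scatter) when (4-fluorophenyl)carbamoyl replaces benzyl. The earlier compounds shown here could not show this, since neither compound 2 nor compound 3 is linked to compound 1 by a single change, and here both the group that leaves and the group that enters carry one six-membered aromatic ring of carbon only, so the step goes with what else differs: the nitrogen, the added oxygen, the fluorine, the double bond outside aromatic rings, and the added hydrogen-bond donor and acceptor. Nothing at hand gives a reason for the rise or assigns it to any one of these parts.

Open, going by these compounds, is whether the fluorine or the carbamoyl link goes with the higher reading, which a plain phenylcarbamoyl, a chloro in place of the fluorine, or an acetyl on the same oxygen would help to separate. Also open, on these data alone, is how the carbamoyl group behaves with a longer chain in place of the aryl ring, and how the reading changes at other concentrations, since a single-concentration percentage is not a potency.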